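A shorter benzylic link on a shared dioxide scaffold

The source may hold more compounds than are shown below. What is called first, only, known or untested is meant among the compounds shown, and "the series" means these compounds.

Compound 1, `COc1ccc2c(c1)[n+]([O-])nc(NCOC(C)c1ccccc1)[n+]2[O-]`, gives 4140 nM in a functional assay on PC-3 cells (Homo sapiens) for cytotoxicity, read by MTT assay, with a stated time of 72 h; a lower number here means a stronger inhibitor, a higher number a weaker inhibitor.
Compound 2, `CC(C)CCOCNc1n[n+]([O-])c2ccccc2[n+]1[O-]`, gives 11100 nM in this assay.
Compound 3, `CC(OCNc1n[n+]([O-])c2ccccc2[n+]1[O-])c1ccccc1`, gives 6080 nM in this assay.

Among these three numbers compound 1 stands lowest; compound 3 lies within the scatter of it, by a 1.5-fold higher number from compound 1 to compound 3 (0.17 log units; within the scatter), while compound 2 lies beyond it. Compound 4, `COc1ccc2c(c1)[n+]([O-])nc(NCOCc1ccccc1)[n+]2[O-]`, differs from compound 1 by hydrogen in place of methyl on a saturated chain carbon bound to an aromatic carbon and an oxygen on a saturated carbon. Among the measured compounds shown here, no measured step touches this chain carbon: the only single-point step, a 1.5-fold higher number from compound 1 to compound 3 (0.17 log units; within the scatter), concerns the aromatic methoxy and stays within the scatter, and compound 2, carrying a different chain altogether, merely shows a higher number than compound 1. No step beyond the scatter is therefore expected in this assay. Compound 4 is estimated at 5000 nM, between 2000 nM and 12500 nM. For compound 4 this amounts to an expected step of a 1.2-fold higher number from compound 1 to compound 4 (0.08 log units; within the scatter).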

Compound 4, half-maximal inhibitory concentration: 8580 nM
Compound 4: middle estimate off by 1.7-fold (0.23 log units), on the low side, and the stated range covers the measured number.
By their numbers in this assay, from the lowest: compounds 1, 3, 4 and 2 (each within the scatter of the next, the first and the last beyond it).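

In this assay, among the compounds shown here, the change from 1-phenylethyl to benzyl gives the first measured step at this chain carbon, a modest one (a 2.1-fold higher number from compound 1 to compound 4 (0.32 log units; beyond the scatter)), whereas the only earlier step (a 1.5-fold higher number from compound 1 to compound 3 (0.17 log units; within the scatter)) concerned the aromatic methoxy. On the core of compound 1, removing this methyl therefore gives a weaker inhibitor. No available evidence accounts for this step. From the compounds shown here alone, whether an ethyl or a longer chain on this carbon would lower or raise the number remains open. So does whether the same change would give a similar step without the methoxy.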